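A few compounds are considered here, and "the series" means these few. Any claim that something is new, unique, unknown or untested is made for them only; others in the source may bear on it.

Three compounds share one core and differ only in the group carried on one nitrogen of that core. Compound 1 `O=C(CCCCCCNc1c(Nc2ccccc2)c(=O)c1=O)NO`, compound 2 `O=C(CCCCCNc1c(NCc2ccccc2)c(=O)c1=O)NO` and compound 3 `CC[C@H](Nc1c(NCCCCCC(=O)NO)c(=O)c1=O)c1ccccc1` have all been tested in an ADME assay on cells (Hepatocyte, Homo sapiens) for pharmacokinetics, read by LC-MS, with a stated time of 90 min, tested at 1 uM; a lower number here means slower removal, a higher number faster removal of the compound. In this assay compound 1 gives < 5 uL/min, which is a limit of the assay rather than a number. Compound 2 gives < 4.8 uL/min, again a limit. Compound 3 gives < 5 uL/min, also a limit. Compound 2 therefore stands at a limit, and the two other values shown are limits as well: two sit at the limit of < 5 uL/min in this assay, at which 2 of the 3 values shown sit, and one at the limit of < 4.8 uL/min in this assay, at which 1 of the 3 values shown sits.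

The only single-point step among these three, a step that the two limits leave unreadable from compound 2 to compound 3, is ethyl in place of hydrogen on a saturated chain carbon bound to an aromatic carbon and a nitrogen on an aromatic ring, and its size cannot be read.

The next compound, compound 4 `Cc1ccc(Nc2c(NCCCCCC(=O)NO)c(=O)c2=O)cc1`, differs from compound 2 by 4-methylphenyl in place of benzyl on a nitrogen on an aromatic ring; cut one bond further out, the same difference reads benzylamino to (4-methylphenyl)amino. No readable step bears on this change, so no direction can be argued from the data. Given that every value so far is a limit, the step that the limit leaves unreadable from compound 2 to compound 4 is expected to be none beyond the scatter. Compound 4 is estimated at 4 uL/min, within 2 uL/min to 10 uL/min.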

Compound 4, intrinsic clearance in a liver preparation (reported as CLH), per the amount of preparation that the assay uses: 7.2 uL/min
Compound 4: middle estimate off by 1.8-fold (0.26 log units), on the low side, and the stated range covers the measured number.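

In this assay, among these compounds, compound 4 gives 7.2 uL/min, the first value in this set that is a number and not a limit, which shows that a compound built on this shared core can give a readable result here. Changing benzyl to 4-methylphenyl on a nitrogen on an aromatic ring, with the same count of carbon atoms entering as leaving, gives an at least 1.5-fold higher number from compound 2 to compound 4 (0.17 log units; that floor lies within the scatter). The true step may be larger, but the pair cannot be separated on this floor alone, and the steps that rest on limits on both sides cannot be read, as compound 2 itself stands at a limit: the limit of < 4.8 uL/min in this assay, at which 1 of the 4 values shown sits.

The compounds shown leave open whether the methyl group or the loss of the saturated carbon of benzyl matters more, and plain phenyl on the same chain as in compound 4 would help to separate the two. Also open, on these data alone, is how this number would respond to other groups in the same place, such as 4-fluorophenyl, or a phenyl ring carrying an amine or a carboxylic acid.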